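Cyano to methyl on a 1,2,5-oxadiazole

A few compounds are considered here, and "the series" means these few. Any claim that something is new, unique, unknown or untested is made for them only; others in the source may bear on it.

Of the compounds shown here, two built on one shared core have been measured so far. In a functional assay (muscle tissue) with Rattus norvegicus as the target (a lower number here means that less compound is needed, a higher number that more compound is needed for the effect), compound 1 `CO/C(O)=C1/C(C)=NC(C)=C([N+](=O)[O-])C1c1ccccc1OCc1no[n+]([O-])c1C` gives 100 nM. In the same test compound 2 `CO/C(O)=C1/C(C)=NC(C)=C([N+](=O)[O-])C1c1ccccc1OCc1nonc1C#N` gives 120 nM, which places it level with compound 1 within the scatter.

The next compound, compound 3 `CO/C(O)=C1/C(C)=NC(C)=C([N+](=O)[O-])C1c1ccccc1OCc1nonc1C`, carries methyl in place of cyano on an aromatic carbon, turning the (4-cyano-1,2,5-oxadiazol-3-yl)methoxy group of compound 2 into (4-methyl-1,2,5-oxadiazol-3-yl)methoxy: methyl in place of cyano on an aromatic carbon. Among the compounds with values here, no measured step covers this exchange directly. Within the data shown here, the nearest guide is the only step available, a 1.2-fold higher number from compound 1 to compound 2 (0.08 log units; within the scatter), in which one five-membered aromatic ring group replaced another and the number stayed within the scatter. One small step is thin evidence, so the range is kept wide, but no shift beyond the scatter is expected in this assay, and no direction is favoured with any confidence. The expected change is a 1.1-fold higher number from compound 2 to compound 3 (0.03 log units; within the scatter). For compound 3 the estimated value is 130 nM, with an expected range from 40 nM to 420 nM.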

Compound 3, half-maximal effective concentration: 57 nM
Compound 3: the middle estimate sits 2.3-fold (0.36 log units) above what was measured, and the stated range covers the measured number.
By their numbers in this assay, from the lowest: compounds 3, 1 and 2 (each within the scatter of the next, the first and the last beyond it).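

At the aromatic carbon that carries cyano in compound 2, the number in this assay does respond to the substituent: methyl in place of cyano gives a 2.1-fold lower number from compound 2 to compound 3 (0.32 log units; beyond the scatter), the only step among these three compounds that passes beyond the scatter, and a modest one. The comparison with compound 1 gives a 1.8-fold lower number from compound 1 to compound 3 (0.24 log units; within the scatter), so compound 1 cannot be separated from either of the other two, and only the cyano and methyl compounds stand apart from each other. No measurement shown here bears on what lies behind this step.

On these data alone, it remains open whether other groups on this aromatic carbon, such as an amine, a carboxylic acid or a longer chain, would give numbers nearer to that of the methyl compound or the cyano compound in this assay. The exchange of cyano for methyl also appears here in one setting only, on the shared core of these compounds, so whether a step of this size would recur on another core is unknown.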